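Swapping the ring on the chain of compound 1

A few compounds are considered here, and "the series" means these few. Any claim that something is new, unique, unknown or untested is made for them only; others in the source may bear on it.

Measured so far:
compound 1, `O=C1O/C(=C\Cn2c(=O)[nH]c(=O)[nH]c2=O)C(OCc2ccccc2)=C1OCc1ccccc1` — 37900 nM
compound 2, `O=C1O/C(=C\Cn2ccc(NC(=O)c3ccccc3)nc2=O)C(OCc2ccccc2)=C1OCc1ccccc1` — 24200 nM
compound 3, `NC1(CCn2ncc(=O)[nH]c2=O)OC(=O)C(OCc2ccccc2)=C1OCc1ccccc1` — a limit, > 100000 nM

In a functional assay on MIA PaCa-2 cells (Homo sapiens) for inhibition, read by MTT assay, with a stated time of 72 h (a lower number here means a stronger inhibitor, a higher number a weaker inhibitor), compound 1 gives 37900 nM. Compound 2 gives 24200 nM in this assay, and the two numbers lie within the usual scatter of each other, so nothing separates them. For compound 3 this assay reports only a limit, > 100000 nM, and no number.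

Compound 4, `O=C1O/C(=C\Cn2ncc(=O)[nH]c2=O)C(OCc2ccccc2)=C1OCc1ccccc1`, has not yet been measured. It differs from compound 1 in one place: a group of 8 heavy atoms (3 carbon, 3 nitrogen, 2 oxygen; one six-membered aromatic ring with 3 hetero atoms) in place of a group of 9 heavy atoms (3 carbon, 3 nitrogen, 3 oxygen; one six-membered aromatic ring with 3 hetero atoms), on a saturated chain carbon bound to a double-bonded chain carbon. Within the data shown here, no step between measured compounds covers this change, so the expected direction has to be read from the compounds at hand. Compound 3, which carries the same entering group on a different core, reaches only a limit in this assay, and compound 1 is itself weak, so compound 4 is expected to stay weak as well. The expected step of a 1.3-fold higher number from compound 1 to compound 4 (0.12 log units; within the scatter) is small and, if anything, toward a higher number. Compound 4 is estimated at 50000 nM, with a range from 20000 nM to 150000 nM.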

Compound 4, half-maximal inhibitory concentration: 20400 nM
The estimate for compound 4 lay 2.5-fold (0.39 log units) above the measured number; the measured number falls inside the stated range.
By their numbers in this assay, from the lowest: compounds 4, 2 and 1 (each within the scatter of the next). At a limit, above all of these: compound 3.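

On the core of compound 1, on a saturated chain carbon bound to a double-bonded chain carbon, the group of 8 heavy atoms in place of the group of 9 heavy atoms gives a 1.9-fold lower number from compound 1 to compound 4 (0.27 log units; within the scatter) in this assay. This exchange, with 1 hydrogen-bond donor entering and 2 hydrogen-bond donors leaving, therefore separates the two compounds by no more than the scatter. Compound 3, which carries the same entering group on a different core, is reported only as a limit: the limit of > 100000 nM in this assay, at which 1 of the 4 values shown sits.

The compounds shown do not tell whether a phenyl ring, a carboxylic acid or an amine at this place would move the number beyond the scatter. Going by these compounds, how a longer chain between the core and the ring would read also stays open.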